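A few compounds are considered here, and "the series" means these few. Any claim that something is new, unique, unknown or untested is made for them only; others in the source may bear on it.

Working notes on the series. In a functional assay, read by spectrophotometry, tested at 100 uM (on this read-out lower numbers stand for stronger inhibition and higher numbers for weaker inhibition), compound 1 `Cc1ccc(/C=C/C(=O)c2cccc(NC(=O)c3cc(-c4ccncc4)n[nH]3)c2)cc1` gives 69400 nM and compound 2 `O=C(/C=C/c1ccc(Cl)cc1)c1cccc(NC(=O)c2cc(-c3ccncc3)n[nH]2)c1` gives 63900 nM. Compound 2 therefore stands level with compound 1, as the two numbers lie within the scatter of each other.

Compound 3 `O=C(/C=C/c1cccs1)c1cccc(NC(=O)c2cc(-c3ccncc3)n[nH]2)c1` has not yet been measured in this assay. It carries thiophen-2-yl in place of 4-chlorophenyl on a double-bonded chain carbon bound to a double-bonded chain carbon.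

For the measured compounds named here, only one measured step bears on this change: a 1.1-fold lower number from compound 1 to compound 2 (0.04 log units; within the scatter), with chloro in place of methyl on an aromatic carbon. That step stays within the scatter, but it exchanges only a substituent on the aromatic group. Going by the values given here, the new change replaces the whole group, and no measured pair shows such a replacement. The evidence is thin, so the range is kept wide, although no shift beyond the scatter is expected in this assay.

The expected step is a 1.0-fold lower number from compound 2 to compound 3 (0.01 log units; within the scatter). For compound 3 the estimated value is 62000 nM, with an expected range from 30000 nM to 100000 nM.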

Compound 3, half-maximal inhibitory concentration: 27600 nM
Compound 3: the middle estimate sits 2.2-fold (0.35 log units) above what was measured; measured number below the stated range.
By their numbers in this assay, from the lowest: compound 3; then compounds 2 and 1 (each within the scatter of the next).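

Within this assay, exchanging the whole aromatic group at this position gives a 2.3-fold lower number from compound 2 to compound 3 (0.36 log units; beyond the scatter) and a 2.5-fold lower number from compound 1 to compound 3 (0.40 log units; beyond the scatter), whereas exchanging only its substituent gave a 1.1-fold lower number from compound 1 to compound 2 (0.04 log units; within the scatter). For the compounds shown here, compound 3, carrying thiophen-2-yl on a double-bonded chain carbon bound to a double-bonded chain carbon, is thus the first compound to separate from the others, and this position responds to a change of the group itself, though only modestly in the one exchange seen. Nothing at hand accounts for this shift, and the change from a six-membered aromatic ring of carbon only to a five-membered aromatic ring with a sulfur atom cannot be divided into separate contributions.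

The compounds shown leave open whether the lower number belongs to thiophen-2-yl in particular or extends to close relatives such as thiophen-3-yl or furan-2-yl. Going by these compounds, it also remains open whether a plain phenyl group, with neither chloro nor methyl, would stand with compound 2 or with compound 3.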